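Hydrogen in place of chloro on compound 3

This account rests on a few compounds, and the source may have more. Where it says the series, first, only, none or still open, it means among the compounds named here.

In an ADME assay on HeLa cells (Homo sapiens) for cytotoxicity, read by MTT assay (a higher number here means a weaker inhibitor, a lower number a stronger inhibitor), compound 1 `CCN(CC)C(=O)COc1ccc(C[C@H]2C(=O)OC[C@@H]2Cc2ccc(OC)c(OC)c2)cc1OC` gives 188000 nM. Compound 2 `COc1ccc(C[C@H]2COC(=O)[C@@H]2Cc2ccc(OCC(=O)N3CCCC3)c(OC)c2)cc1OC` is reported only as a limit, >= 600000 nM. Compound 3 `COc1ccc(C[C@H]2COC(=O)[C@@H]2Cc2ccc(OCc3cn(-c4ccc(Cl)cc4)nn3)c(OC)c2)cc1OC` gives 279000 nM, which lies within the scatter of compound 1. Compound 4 `COc1ccc(C[C@H]2COC(=O)[C@@H]2Cc2ccc(OCc3cn(-c4ccccc4)nn3)c(OC)c2)cc1OC` differs from compound 3 by hydrogen in place of chloro on an aromatic carbon, para to a large group, so that 4-chlorophenyl becomes phenyl.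

Among the compounds with values here, no measured step makes this change alone. The nearest evidence comes from two swaps of the whole 1-(4-chlorophenyl)-1H-1,2,3-triazol-4-yl group. One is a 1.5-fold higher number from compound 1 to compound 3 (0.17 log units; within the scatter), which stays within the scatter. The other is an at least 2.1-fold lower number from compound 2 to compound 3 (0.33 log units; beyond the scatter), which is beyond the scatter but rests on a limit, so it gives no firm size. Neither isolates the chloro, so no step beyond the scatter is expected in this assay. The expected change is small, a 1.1-fold higher number from compound 3 to compound 4 (0.03 log units; within the scatter). For compound 4 the estimated value is 300000 nM, with an expected range of 150000 nM to 600000 nM.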

Compound 4, half-maximal inhibitory concentration: 124000 nM
For compound 4 the middle estimate is 2.4-fold (0.38 log units) above the measured one, and the stated range ends above it.
By their numbers in this assay, from the lowest: compounds 4, 1 and 3 (each within the scatter of the next, the first and the last beyond it). At a limit, above all of these: compound 2.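

Hydrogen in place of chloro on an aromatic carbon, para to a large group, now has a step of its own in this assay, and it gives a 2.3-fold lower number from compound 3 to compound 4 (0.35 log units; beyond the scatter), a modest change beyond the scatter that the swaps of the whole triazole group could not isolate. Against diethylcarbamoyl, the 1-phenyl-1H-1,2,3-triazol-4-yl group gives a 1.5-fold lower number from compound 1 to compound 4 (0.18 log units; within the scatter), which stays within the scatter. Against (pyrrolidin-1-yl)carbonyl, the same group gives an at least 4.8-fold lower number from compound 2 to compound 4 (0.68 log units; beyond the scatter), a step that starts from a limit and so has no firm size: the limit of >= 600000 nM in this assay, at which 1 of the 4 values shown sits.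

The compounds shown leave open how other groups at this place on the phenyl ring would read, such as fluoro, methoxy or a carboxylic acid. On these data alone, the change also rests on a single pair, so whether it holds on any other core remains open.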